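The compounds below may be only part of what the source reports. "The series", "measured", "known", "first", "only" and "open" are said of these compounds alone.

Measured in an ADME assay on HeLa cells (Homo sapiens) for cytotoxicity, read by MTT assay; a lower number here means a stronger inhibitor, a higher number a weaker inhibitor:
- Compound 1 `COc1ccc(C[C@H]2COC(=O)[C@@H]2Cc2ccc(OCc3cn(-c4ccc(F)cc4)nn3)c(OC)c2)cc1OC`: >= 600000 nM, a limit of the assay and not a number
- Compound 2 `CCN(CC)C(=O)COc1ccc(C[C@H]2C(=O)OC[C@@H]2Cc2ccc(OC)c(OC)c2)cc1OC`: 188000 nM
- Compound 3 `COc1ccc(C[C@H]2COC(=O)[C@@H]2Cc2ccc(OCc3cn(Cc4ccccc4Cl)nn3)c(OC)c2)cc1OC`: 84500 nM

Not yet measured:
- Compound 4 `COc1ccc(C[C@H]2COC(=O)[C@@H]2Cc2ccc(OCc3cn(Cc4ccccc4)nn3)c(OC)c2)cc1OC`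

Of the two true numbers, compound 3 at 84500 nM has the lower one, and compound 2 at 188000 nM lies higher by more than the scatter. Compound 4 differs from compound 3 in one small place, with hydrogen in place of chloro on an aromatic carbon, so that 2-chlorobenzyl becomes benzyl: hydrogen in place of chloro on an aromatic carbon.

The closest evidence is an at least 7.1-fold lower number from compound 1 to compound 3 (0.85 log units; beyond the scatter), where 2-chlorobenzyl replaces 4-fluorophenyl on an aromatic nitrogen. A second change, an at least 3.1-fold lower number from compound 1 to compound 2 (0.50 log units; beyond the scatter), swaps a larger part of the molecule and bears on this question less directly. Both steps start from a limit, so their sizes are only minimums, and neither removes the chloro alone. A small step is therefore expected in this assay. Compound 3 already has the lower of the two true numbers at 84500 nM, so any drift is expected toward a higher number. The estimated change is a 1.5-fold higher number from compound 3 to compound 4 (0.19 log units; within the scatter). Compound 4 is expected at about 130000 nM, with an estimated range of 50000 nM to 350000 nM.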

Compound 4, half-maximal inhibitory concentration: 346000 nM
Beside the measured number, compound 4's estimate is 2.7-fold (0.43 log units) below it; the measured number falls inside the stated range.
By their numbers in this assay, from the lowest: compound 3; then compounds 2 and 4 (each within the scatter of the next). At a limit, above all of these: compound 1.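

In this assay, taking away the single chlorine of the 2-chlorobenzyl group and leaving hydrogen on that aromatic carbon, ortho to a large group, gives a 4.1-fold higher number from compound 3 to compound 4 (0.61 log units; beyond the scatter). This is the first step shown that isolates the chloro, and it shows that this one atom alone moves the number by more than the usual scatter, with the chlorinated compound 3 the stronger of the pair. Without the chloro, the 1-benzyl-1H-1,2,3-triazol-4-yl group no longer stands apart from the diethylcarbamoyl group, as a 1.8-fold higher number from compound 2 to compound 4 (0.26 log units; within the scatter) stays too small to rank the two. Benzyl in place of 4-fluorophenyl on an aromatic nitrogen gives an at least 1.7-fold lower number from compound 1 to compound 4 (0.23 log units; that floor lies within the scatter), and this size is only a minimum. Compound 1 stands at a limit and not at a true number: the limit of >= 600000 nM in this assay, at which 1 of the 4 values shown sits.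

As far as these compounds go, whether this gain belongs to chlorine itself or would come with any group on that carbon stays open, since a fluoro, a bromo or a methyl group in the same place would be needed to tell these apart. Also open is whether chloro would do the same on another carbon of that ring, and the numbers shown give no cause for the effect.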